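This account rests on a few compounds, and the source may have more. Where it says the series, first, only, none or still open, it means among the compounds named here.

Among the compounds with values here, compound 1, with the structure `CC(C(=O)N1CCN(c2cccc(Cl)c2)CC1)N1C(=O)CCC1=O`, stands highest of the two compounds measured so far. In a functional assay on the whole organism (strain Swiss) with Mus musculus as the target, in the maximal electroshock model, with a stated time of 0.25 h, at a dose of 100 mg/kg by the intraperitoneal route (a lower number here means a weaker effect, a higher number a stronger effect of the compound at the dose given), compound 1 gives 50%, while compound 2, with the structure `CCC(C(=O)N1CCN(c2ccccc2)CC1)N1C(=O)CCC1=O`, gives in this assay a value of 25%, a number that lies beyond the usual scatter below compound 1. Compound 2 differs from compound 1 in more than one place, so no single step can be read from that pair.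

Compound 3, with the structure `CC(C(=O)N1CCN(c2cccc(F)c2)CC1)N1C(=O)CCC1=O`, has not yet been measured. It differs from compound 1 by the change (fluoro in place of chloro on an aromatic carbon). Within the data shown here, since no measured pair shows this same change, the expected size of the step rests only on the closeness of the two structures: the step from compound 1 to compound 3 in this assay is expected to be small, a number 8 percentage points lower from compound 1 to compound 3 (within the scatter), most likely within the scatter and, if anything, slightly downward. For compound 3 the estimated value in this assay is 42%, within a range from 20% to 65%.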

Compound 3, a percentage reported as activity, at one dose (the size of the read-out at that dose, not a potency): 75%
Beside the measured number, compound 3's estimate is 33 percentage points below it; measured number outside the range, above it.
By their numbers in this assay, from the lowest: compound 2; then compound 1; then compound 3.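

Within the data shown here, the 3-chlorophenyl to 3-fluorophenyl change gives the first step that can be read at a single place, and in this assay it is a clear gain (a number 25 percentage points higher from compound 1 to compound 3 (beyond the scatter)). This place on the aromatic ring is therefore not indifferent to which halogen it carries: exchanging one heavy atom for another, with no change in ring, hydrogen-bond donors, hydrogen-bond acceptors or net charge, moves the read-out beyond the scatter. Nothing at hand accounts for the size or direction of this step.

The compounds shown leave open whether this place also accepts a group other than a halogen, such as methoxy, an amine or trifluoromethyl. They also leave open how the same compound would respond with fluoro elsewhere on the ring.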